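From oxolan-3-yl to oxolan-2-yl: compound 1 to compound 3

This account rests on a few compounds, and the source may have more. Where it says the series, first, only, none or still open, it means among the compounds named here.

- compound 1 `Cc1cc(C)c(CN2CCc3c(Cl)cc([C@@H](CO)[C@@H]4CCOC4)c(Cl)c3C2=O)c(=O)[nH]1` gives 3 10^-6 cm/s
- compound 2 `COC(C)c1cc(Cl)c2c(c1Cl)C(=O)N(Cc1c(C)cc(C)[nH]c1=O)CC2` gives 26 10^-6 cm/s; 37.6 10^-6 cm/s (2 entries)

Among the compounds with values here, in an ADME assay on MDCK cells (Canis lupus familiaris) for permeability, read by LC-MS, with a stated time of 90 min, tested at 2 uM (on this read-out higher numbers stand for higher permeability and lower numbers for lower permeability), compound 1 stands at 3 10^-6 cm/s as its only number, with one further entry lacking a single number, and it lies under compound 2 at 26 10^-6 cm/s; 37.6 10^-6 cm/s (2 entries) on these values. Compound 3 `Cc1cc(C)c(CN2CCc3c(Cl)cc([C@@H](CO)[C@H]4CCCO4)c(Cl)c3C2=O)c(=O)[nH]1` differs from compound 1 by oxolan-2-yl in place of oxolan-3-yl on a saturated chain carbon bound to an aromatic carbon and a saturated chain carbon and has the same atoms, joined differently. Within the data shown here, no measured step covers this change, so the expectation in this assay is a step within the scatter, with no firm direction. The expected 1.2-fold higher number from compound 1 to compound 3 (0.07 log units; within the scatter) is small and is anchored on compound 1 at 3 10^-6 cm/s. For compound 3 the estimate is 3.5 10^-6 cm/s, with an expected range of 1.3 10^-6 cm/s to 9 10^-6 cm/s.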

Compound 3, apparent permeability: 8.5 10^-6 cm/s
Estimate against measurement, compound 3: 2.4-fold (0.39 log units) below, within the range that was stated.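

In this assay, oxolan-2-yl in place of oxolan-3-yl on the saturated chain carbon gives a 2.8-fold higher number from compound 1 to compound 3 (0.45 log units; beyond the scatter), with the atoms and the counted donors and acceptors unchanged. This is the only single-place step shown, so the read-out at this position responds to how the ring is joined, not only to which atoms are present. The step is modest, and repeat readings in this read-out also differ: the several entries of compound 2 in this assay, 26 10^-6 cm/s; 37.6 10^-6 cm/s (2 entries)

Open, on these data alone, is whether the opposite stereocentre of oxolan-2-yl reads the same. Also open, as far as these compounds go, is how a pyrrolidin-2-yl amine or a longer chain would read at this place.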